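The compounds below may be only part of what the source reports. "The series", "measured", "known", "first", "only" and "open" are said of these compounds alone.

Measured so far:
- Compound 1 `CC(Oc1ccc(-c2ccccc2)cc1)C(=O)Cn1nnc(-c2ccccc2)n1`: 15 nM
- Compound 2 `CC(Oc1ccc(Oc2ccc(Cl)cc2)cc1)C(=O)Cn1nnc(-c2ccc(Cl)cc2)n1`: 76 nM

Both compounds were tested in an assay on microsomes from brain for inhibition of Fatty-acid amide hydrolase 1 (Rattus norvegicus), read by fluorescence and HPLC, with a stated time of 60 min; a lower number here means a stronger inhibitor, a higher number a weaker inhibitor. Compound 1 gives 15 nM, while compound 2 gives 76 nM, which is the higher of the two numbers and therefore the weaker of the two inhibitors; the gap between them is beyond the usual scatter of this assay. No single-point comparison between the two is available, since they differ at two places at once.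

Compound 3 `CC(Oc1ccc(-c2ccccc2)cc1)C(=O)Cn1nnc(-c2ccc(Cl)cc2)n1` is the next compound to be measured. Relative to compound 2, the change is phenyl in place of 4-chlorophenoxy on an aromatic carbon. Compound 3 thus shares part of its structure with each of the measured compounds: the biphenyl portion of compound 1 and the chlorinated tetrazole substituent of compound 2.

For the measured compounds named here, with no directly comparable step on record, the expectation is that compound 3 moves toward compound 1, with a modest step downward, a 2.5-fold lower number from compound 2 to compound 3 (0.40 log units; beyond the scatter), in this assay. Compound 3 is therefore estimated at 30 nM, within a range of 10 nM to 90 nM.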

Compound 3, half-maximal inhibitory concentration: 25 nM
Compound 3: the middle estimate sits 1.2-fold (0.08 log units) above what was measured, within the range that was stated.
By their numbers in this assay, from the lowest: compounds 1 and 3 (each within the scatter of the next); then compound 2.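

In this assay, putting phenyl in place of 4-chlorophenoxy on an aromatic carbon gives a 3.0-fold lower number from compound 2 to compound 3 (0.48 log units; beyond the scatter), so the group held at this spot, para to a large group, clearly affects the read-out. The second single change, chloro in place of hydrogen on an aromatic carbon, gives a 1.7-fold higher number from compound 1 to compound 3 (0.22 log units; within the scatter); this lies within the usual scatter, so this comparison shows no real effect of adding the chloro group. Nothing measured here explains why the first change matters and the second does not.

The compounds shown do not reveal how a methoxy group or a pyridyl ring would behave in place of phenyl, or whether plain phenoxy would give a different number from 4-chlorophenoxy, which would separate the role of the chlorine from that of the linking oxygen. They also leave open whether a fluoro or nitrile group would match chloro on the aromatic carbon where it replaced hydrogen, since that single comparison covers only chloro and hydrogen.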